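A pyridin-2-yl swap at the assay limit

A few compounds are considered here, and "the series" means these few. Any claim that something is new, unique, unknown or untested is made for them only; others in the source may bear on it.

Measured so far in an ADME assay on MDBK cells (Bos taurus) for cytotoxicity; a lower number here means that less compound is tolerated, a higher number that more compound is tolerated:
Compound 1 `COc1ccccc1Cn1ccc2nc(-c3ccccc3)nc-2c1` gives > 100000 nM as a limit
Compound 2 `N#Cc1ccc(Cn2ccc3nc(-c4ccccc4)nc-3c2)cc1` gives > 100000 nM as a limit
Compound 3 `CCn1ccc2nc(-c3ccccc3)nc-2c1` gives > 100000 nM as a limit

Compound 3 thus stands at a limit and not at a number (> 100000 nM). Within the data shown here, no compound here has left that limit (the limit of > 100000 nM in this assay, at which 3 of the 3 values shown sit). Compound 4 `c1ccc(-c2nc3ccn(Cc4ccccn4)cc-3n2)cc1` differs from compound 3 by one change (pyridin-2-yl in place of methyl on a saturated chain carbon bound to an aromatic nitrogen), with pyridin-2-yl in place of methyl on a saturated chain carbon bound to an aromatic nitrogen. The measured steps at that same place are a step that the two limits leave unreadable from compound 1 to compound 2 and a step that the two limits leave unreadable from compound 1 to compound 3 and also a step that the two limits leave unreadable from compound 2 to compound 3 and none of them has a readable size. Among the measured compounds shown here, they offer no sign that changing this group moves the result, so no step of readable size is expected in this assay and no direction can be given. The expected change is a number no higher from compound 3 to compound 4 (the limit leaves the size open) and nothing larger is anticipated. Compound 4 is estimated at 100000 nM (expected range 40000 nM to 200000 nM) and will probably be reported only as a limit.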

Compound 4, half-maximal cytotoxic concentration: > 100000 nM
Compound 4 ended at the assay's limit; the forecaster's own chance of this, stated with the estimate: 85%; the middle value sits exactly at the limit.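

In this assay compound 4 gives > 100000 nM, a limit and not a number. Among these compounds, no step from compound 1, compound 2 or compound 3 to compound 4 can be read: the limit of > 100000 nM in this assay, at which 4 of the 4 values shown sit. The compounds shown leave open whether changing this group moves the tolerated concentration at all.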